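Small amine variations at one position of a shared core

The compounds below may be only part of what the source reports. "The series", "measured", "known", "first", "only" and "open" are said of these compounds alone.

Measured compounds:
Compound 1 `FC(F)(F)c1ccc(Nc2nc(N3CCC3)nc3sc(Nc4c(Cl)cccc4Cl)nc23)cc1` gives 25 nM in a functional assay on HEK293 cells for antagonist activity at transient receptor potential cation channel subfamily V member 1 (Rattus norvegicus), read by calcium flux; a higher number here means a weaker inhibitor, a lower number a stronger inhibitor.
Compound 2 `CC(C)N1CCN(c2nc(Nc3ccc(C(F)(F)F)cc3)c3nc(Nc4c(Cl)cccc4Cl)sc3n2)CC1` gives 119 nM in this assay.
Compound 3 `CN(C)c1nc(Nc2ccc(C(F)(F)F)cc2)c2nc(Nc3c(Cl)cccc3Cl)sc2n1` gives 43 nM in this assay.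

Compound 3 has the second highest of the three numbers. Its nearest neighbour is compound 1, a gap within the usual scatter, while compound 2 sits further away, beyond the scatter. All three share one core and differ only in the amine attached to one aromatic carbon.

Compound 4 `CCN(CC)c1nc(Nc2ccc(C(F)(F)F)cc2)c2nc(Nc3c(Cl)cccc3Cl)sc2n1` carries the change (diethylamino in place of dimethylamino on an aromatic carbon). Going by the values given here, two measured steps bear on this. The step of a 1.7-fold higher number from compound 1 to compound 3 (0.24 log units; within the scatter) shows that exchanging the small ring amine of compound 1 for an open-chain dimethylamino barely changes the number. The step of a 2.8-fold lower number from compound 2 to compound 3 (0.44 log units; beyond the scatter), together with a 4.8-fold higher number from compound 1 to compound 2 (0.68 log units; beyond the scatter), shows that the largest amine of the set, in compound 2, gives a noticeably higher number. Diethylamino is larger than dimethylamino yet much smaller than the group in compound 2, so only a small shift, if any, is expected in this assay, if anything towards a higher number.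

Compound 4 is therefore expected to give about 60 nM, with a likely range from 25 nM to 150 nM. This estimate means a step of a 1.4-fold higher number from compound 3 to compound 4 (0.14 log units; within the scatter), expected to lie within or close to the scatter.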

Compound 4, half-maximal inhibitory concentration: 34 nM
The estimate for compound 4 lay 1.8-fold (0.25 log units) above the measured number; low and high end bracket the measured number.
By their numbers in this assay, from the lowest: compounds 1, 4 and 3 (each within the scatter of the next); then compound 2.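

Going from dimethylamino to diethylamino gives a 1.3-fold lower number from compound 3 to compound 4 (0.10 log units; within the scatter) in this assay, so this longer open-chain amine cannot be told apart from the shorter one. The same holds against the ring amine azetidin-1-yl, with a 1.4-fold higher number from compound 1 to compound 4 (0.13 log units; within the scatter) as the step. The position therefore accepts a group with more heavy atoms than dimethylamino without a readable change, and among these four compounds only the 4-isopropylpiperazin-1-yl group stands apart, with a 3.5-fold lower number from compound 2 to compound 4 (0.54 log units; beyond the scatter) as the step.

The compounds shown leave open where, between diethylamino and 4-isopropylpiperazin-1-yl, the number begins to rise, and a piperidin-1-yl or morpholin-4-yl ring would help to place that point. They also leave open whether the isopropyl group or the second ring nitrogen of compound 2 accounts for its gap, which a plain piperazin-1-yl group could help to separate. No measurement offered here explains why these amines read so alike or why compound 2 differs.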